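This account rests on a few compounds, and the source may have more. Where it says the series, first, only, none or still open, it means among the compounds named here.

Measured compounds in an ADME assay on Vero cells (Chlorocebus sabaeus) for inhibition, read by sulforhodamine B assay, with a stated time of 48 h; a higher number here means a weaker inhibitor of growth, a lower number a stronger inhibitor of growth:
compound 1 `CC1=CC[C@H](C(C)(C)N=C=S)CC1`, reported only as a limit of the assay: > 100000 nM
compound 2 `CC1=CC[C@H](C(C)(C)NC(=S)N/N=C(\C)c2ccccc2)CC1`, reported only as a limit of the assay: > 100000 nM

Working notes. Compound 2 stands nowhere that can be ranked: its value is a limit, not a number, and compound 1 sits at the same limit, so the two show only that neither reaches total growth inhibition within the measured range (the limit of > 100000 nM in this assay, at which 2 of the 2 values shown sit). Within the data shown here, no step between measured compounds can be drawn.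

Compound 3 `CC1=CC[C@H](C(C)(C)NC(=S)N/N=C(\C)c2ccc([N+](=O)[O-])cc2)CC1` is yet to be measured in this assay. Against compound 2 the change is nitro in place of hydrogen on an aromatic carbon. With both measured compounds at the limit, no direction or size of step in this assay can be read from the series, and nothing shown supports a move beyond the scatter.

The expectation for compound 3 is therefore that it again reaches the limit or lands near it, estimated at 100000 nM with a range of 30000 nM to 300000 nM. The step that this estimate implies, a number no higher from compound 2 to compound 3 (the limit leaves the size open), is expected to stay within scatter.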

Compound 3, concentration for total growth inhibition: > 100000 nM
Compound 3: a limit, no number; the forecaster's own chance of this, stated with the estimate: 75%; the middle value lies on the limit itself.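

In this assay, among these compounds, compound 3 is reported only as a limit, as compound 2 is, so no step for nitro in place of hydrogen can be read between compound 2 and compound 3: the limit of > 100000 nM in this assay, at which 3 of the 3 values shown sit. The compounds shown leave open whether any change on the shared core brings total growth inhibition within the measured range.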